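Isopropyl in Place of Methyl: a Step Without Precedent

This account rests on a few compounds, and the source may have more. Where it says the series, first, only, none or still open, it means among the compounds named here.

Measured so far in a functional assay on SW480 cells (Homo sapiens) for antiproliferative activity; a higher number here means a weaker inhibitor, a lower number a stronger inhibitor:
compound 1 `COc1ccccc1/C=C/C(=O)c1ccc(OCCn2cc(CN3C(=O)/C=C/C(C)(C)C/C=C(\C)CC/C=C/3C)nn2)cc1O` gives 0.9 ug/mL
compound 2 `C/C1=C\CC(C)(C)/C=C/C(=O)N(Cc2cn(CCOc3ccc(C(=O)/C=C/c4ccc(C)cc4)c(O)c3)nn2)/C(C)=C/CC1` gives 1.16 ug/mL

Within the data shown here, compound 2 holds the higher of the two numbers in this assay, but its only neighbour is compound 1, and the step of a 1.3-fold higher number from compound 1 to compound 2 (0.11 log units; within the scatter) lies within the scatter, so the two compounds cannot be ranked against each other on these data.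

Compound 3 `C/C1=C\CC(C)(C)/C=C/C(=O)N(Cc2cn(CCOc3ccc(C(=O)/C=C/c4ccc(C(C)C)cc4)c(O)c3)nn2)/C(C)=C/CC1` has not yet been measured. It differs from compound 2 by isopropyl in place of methyl on an aromatic carbon. Among the measured compounds shown here, the single measured step, a 1.3-fold higher number from compound 1 to compound 2 (0.11 log units; within the scatter), concerns a different exchange on that ring and was itself within the scatter; nothing measured here addresses the growth of methyl into isopropyl at this place, so no direction can be read from the data. The step of a 1.0-fold higher number from compound 2 to compound 3 (0.01 log units; within the scatter) is therefore expected to be none beyond the scatter, with a wide allowance either way. On that basis compound 3 is estimated at 1.2 ug/mL in this assay, with a range from 0.5 ug/mL to 3 ug/mL.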

Compound 3, half-maximal inhibitory concentration: 0.85 ug/mL
For compound 3 the middle estimate is 1.4-fold (0.15 log units) above the measured one, within the range that was stated.
By their numbers in this assay, from the lowest: compounds 3, 1 and 2 (each within the scatter of the next).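

In this assay, among these compounds, the exchange of methyl for isopropyl on an aromatic carbon, para to a large group, gives a 1.4-fold lower number from compound 2 to compound 3 (0.14 log units; within the scatter) and so is the first reading of how this place responds to a larger alkyl group: isopropyl, with its three heavy atoms against the single one of methyl, leaves the number within the scatter of that of compound 2. The exchange of the whole aryl group, 4-isopropylphenyl in place of 2-methoxyphenyl, gives a 1.1-fold lower number from compound 1 to compound 3 (0.02 log units; within the scatter) and likewise stays within the scatter, so that the three aryl groups shown on this chain cannot be ranked against one another in this read-out. Nothing available here explains why the numbers stay so close together.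

The compounds shown leave open how far this tolerance reaches, since methyl and isopropyl are the only groups compared at this place and both are plain alkyl groups. Whether an amine, a carboxylic acid or a longer chain such as hexyl at the same aromatic carbon would move the number beyond the scatter, in either direction, remains an open question.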